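Replacing 3-Methoxyphenyl with 2-Phenylethenyl on the Amide Carbonyl

The compounds below may be only part of what the source reports. "The series", "measured", "known", "first", "only" and "open" are said of these compounds alone.

Measured compounds:
- compound 1 `COc1cccc(C(=O)Nc2cc(Sc3ncn[nH]3)c(O)c3ccccc23)c1`: > 100000 nM
- compound 2 `O=C(Nc1cc(Sc2ncn[nH]2)c(O)c2ccccc12)c1cccc(Cl)c1`: > 100000 nM
- compound 3 `COc1ccc(/C=C/C(=O)Nc2cc(Sc3ncn[nH]3)c(O)c3ccccc23)cc1OC`: 52500 nM

All three share one core and differ only in the group attached to the amide carbonyl. In a functional assay on MDA-MB-231 cells (Homo sapiens) for antiproliferative activity, read by MTT assay, with a stated time of 48 h (a higher number here means a weaker inhibitor, a lower number a stronger inhibitor), compound 1 gives > 100000 nM, which is a limit of the assay rather than a number. Compound 2 likewise gives only a limit, > 100000 nM. Compound 3, which carries a double bond between the ring and the carbonyl, gives a measurable 52500 nM.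

Going by the values given here, the only recorded step, a step that the two limits leave unreadable from compound 1 to compound 2, is unreadable, since both ends sit at the limit of > 100000 nM in this assay, at which 2 of the 3 values shown sit. So no measured step speaks directly to the change from compound 1 to compound 4 `O=C(/C=C/c1ccccc1)Nc1cc(Sc2ncn[nH]2)c(O)c2ccccc12`, namely (2-phenylethenyl in place of 3-methoxyphenyl on a carbonyl carbon). Compound 3 shows that a 2-phenylethenyl-type amide can reach a readable value, though without a listed step to compound 1 this is only what its value shows.

Compound 4 is therefore expected to lie near 60000 nM, between 20000 nM and 150000 nM, an expected step of an at least 1.6-fold lower number from compound 1 to compound 4 (0.22 log units; that floor lies within the scatter) from compound 1.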

Compound 4, half-maximal inhibitory concentration: > 100000 nM
Compound 4 gave a limit, no number (the forecaster's own chance of this, stated with the estimate: 40%); at least 1.6-fold (0.22 log units) between middle value and limit.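

Compound 4 gives only a limit in this assay, so the 2-phenylethenyl group on the carbonyl carbon does not by itself produce a readable value. Phenyl in place of 3,4-dimethoxyphenyl on the chain gives an at least 1.9-fold higher number from compound 3 to compound 4 (0.27 log units; that floor lies within the scatter), so this step hints that the two methoxy groups of compound 3 may matter but does not establish it. The steps linking compound 4 to compound 1 and to compound 2 cannot be read, because both ends of each are limits: the limit of > 100000 nM in this assay, at which 3 of the 4 values shown sit.

As far as these compounds go, how compound 1, compound 2 and compound 4 truly compare stays open. Also open, from the compounds shown here alone, is whether an amine or a carboxylic acid on the phenyl ring of the 2-phenylethenyl group, or a longer chain on the carbonyl carbon, would give a readable value in this assay.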